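Varying the group on the triazole nitrogen of the shared core

A few compounds are considered here, and "the series" means these few. Any claim that something is new, unique, unknown or untested is made for them only; others in the source may bear on it.

Compound 1 `COC(=O)Cn1cc(CO[C@H]2CC(=O)[C@@H]3OC[C@H]2O3)nn1` gives 21300 nM in a functional assay on MDA-MB-231 cells (Homo sapiens) for cytotoxicity, read by MTT assay, with a stated time of 48 h (on this read-out lower numbers stand for stronger inhibition and higher numbers for weaker inhibition), the lowest of the three numbers shown, although compound 2 `O=C1C[C@H](OCc2cn(C(=O)c3ccccc3)nn2)[C@H]2CO[C@@H]1O2` with 25900 nM and compound 3 `O=C1C[C@H](OCc2cn(-c3cccc(Cl)c3Cl)nn2)[C@H]2CO[C@@H]1O2` with 26000 nM both lie within the scatter of it. The steps of a 1.2-fold higher number from compound 1 to compound 2 (0.08 log units; within the scatter), a 1.2-fold higher number from compound 1 to compound 3 (0.09 log units; within the scatter) and a 1.0-fold higher number from compound 2 to compound 3 (0.00 log units; within the scatter) show that three quite different groups on the aromatic nitrogen leave the read-out essentially unchanged. Compound 4 `O=C1CCCCC1n1cc(CO[C@H]2CC(=O)[C@@H]3OC[C@H]2O3)nn1` differs from compound 1 by 2-oxocyclohexyl in place of (methoxycarbonyl)methyl on an aromatic nitrogen. Every measured exchange at this position stayed within the scatter; the step of a 1.0-fold higher number from compound 1 to compound 4 (0.01 log units; within the scatter) is expected to stay within it as well. Compound 4 is therefore estimated at 22000 nM, with a range from 11000 nM to 45000 nM.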

Compound 4, half-maximal inhibitory concentration: 36000 nM
The estimate for compound 4 lay 1.6-fold (0.21 log units) below the measured number; low and high end bracket the measured number.
By their numbers in this assay, from the lowest: compounds 1, 2, 3 and 4 (each within the scatter of the next).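

2-oxocyclohexyl, with its six-membered non-aromatic ring of carbon only, also stays within the scatter against each of the other groups on the aromatic nitrogen (a 1.7-fold higher number from compound 1 to compound 4 (0.23 log units; within the scatter); a 1.4-fold higher number from compound 2 to compound 4 (0.14 log units; within the scatter); a 1.4-fold higher number from compound 3 to compound 4 (0.14 log units; within the scatter)). In this assay the flat picture at this position therefore now covers a non-aromatic ring as well as (methoxycarbonyl)methyl, benzoyl and 2,3-dichlorophenyl. No data on hand bear on the reason for this flatness. From the compounds shown here alone, whether an amine, a carboxylic acid or a longer alkyl chain on this nitrogen would give a step beyond the scatter remains open, as does the effect of changes elsewhere on the shared core.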